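Shortening the (pent-2-en-1-yl)oxy group to methoxy

A few compounds are considered here, and "the series" means these few. Any claim that something is new, unique, unknown or untested is made for them only; others in the source may bear on it.

Compound 1 `CC/C=C\COC1(c2ccc(Cl)cc2)SC=C(C)n2c1noc2=O`: 103000 nM
Compound 2 `CC/C=C/COC1(c2ccc(Cl)cc2)SC=C(C)n2c1noc2=O`: 88000 nM
Compound 3 `CC1=CSC(O)(c2ccc(C)cc2)c2noc(=O)n21`: > 100000 nM, which is a limit of the assay rather than a number

In a functional assay on A2780/DX3 cells (Homo sapiens) for antiproliferative activity, read by MTT assay, with a stated time of 3 days (on this read-out higher numbers stand for weaker inhibition and lower numbers for stronger inhibition), compound 2 gives 88000 nM and compound 1 gives 103000 nM. Among the compounds with values here, the only step between measured compounds, a 1.2-fold lower number from compound 1 to compound 2 (0.07 log units; within the scatter), is a change of double bond geometry alone and leaves the two indistinguishable, so compound 2 stands together with compound 1 at the weak end of what was measured. Compound 3 reaches only a limit of the assay, > 100000 nM.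

Compound 4 `COC1(c2ccc(Cl)cc2)SC=C(C)n2c1noc2=O` differs from compound 2 by hydrogen in place of but-1-en-1-yl on a saturated chain carbon bound to an oxygen on a saturated carbon. Within the data shown here, no measured step removes this chain; the one step available changes only its drawn geometry, and that step was within the scatter. The limit of > 100000 nM in this assay, at which 1 of the 3 values shown sits, shows that one compound of this series already fell outside the measurable range. The step from compound 2 to compound 4 is therefore expected to be small in either direction, with a real chance that compound 4 gives only a limit; the expected step is a 1.4-fold higher number from compound 2 to compound 4 (0.13 log units; within the scatter). Compound 4 is estimated at 120000 nM, between 45000 nM and 300000 nM.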

Compound 4, half-maximal inhibitory concentration: 113000 nM
The estimate for compound 4 lay 1.1-fold (0.03 log units) above the measured number; the measured number falls inside the stated range.
By their numbers in this assay, from the lowest: compounds 2, 1 and 4 (each within the scatter of the next).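

In this assay, within the data shown here, the earlier compounds had varied only the double bond geometry of the (pent-2-en-1-yl)oxy group, whereas this result covers the replacement of that whole group by methoxy, and the step stays within the scatter (a 1.3-fold higher number from compound 2 to compound 4 (0.11 log units; within the scatter)) against either isomer (a 1.1-fold higher number from compound 1 to compound 4 (0.04 log units; within the scatter)). The but-1-en-1-yl portion can therefore be replaced by hydrogen with no readable difference in this assay, and compounds 1, 2 and 4 cannot be told apart. Nothing shown explains why these numbers stand together, and no measured property of the group accounts for this result.

On these data alone, it remains open whether a longer chain, an amine or a carboxylic acid in this place would move the number beyond the scatter. As far as these compounds go, it also remains open whether such a change would matter on the core of compound 4 with a different substituent elsewhere.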